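Swapping Isopropyl for Cyclopropyl at the Benzyl End

A few compounds are considered here, and "the series" means these few. Any claim that something is new, unique, unknown or untested is made for them only; others in the source may bear on it.

In an assay on CHO cells for displacement of a labelled ligand from transient receptor potential cation channel subfamily V member 1 (Rattus norvegicus) (a lower number here means a stronger inhibitor, a higher number a weaker inhibitor), compound 3 `CC(C)c1ccc(CNC(=O)C(C)c2ccc(NS(C)(=O)=O)c(F)c2)cc1` gives 127 nM, the lowest of the three numbers. Compound 2 `CC(C(=O)NCc1ccc(Cl)c(Cl)c1)c1ccc(NS(C)(=O)=O)c(F)c1` gives 200 nM, and compound 1 `CC(C(=O)NCc1ccc(Br)cc1)c1ccc(NS(C)(=O)=O)c(F)c1` gives 412 nM. The gap a 1.6-fold lower number from compound 2 to compound 3 (0.20 log units; within the scatter) lies within the scatter, whereas a 3.2-fold lower number from compound 1 to compound 3 (0.51 log units; beyond the scatter) lies beyond it. Compound 4 `CC(C(=O)NCc1ccc(C2CC2)cc1)c1ccc(NS(C)(=O)=O)c(F)c1` differs from compound 3 by cyclopropyl in place of isopropyl on an aromatic carbon. Among the measured compounds shown here, no measured step tests this exact change. The step of a 3.2-fold lower number from compound 1 to compound 3 (0.51 log units; beyond the scatter) shows a modest drop in number when isopropyl replaces bromo, and the step of a 1.6-fold lower number from compound 2 to compound 3 (0.20 log units; within the scatter) shows that two different groups of similar size give numbers within the scatter of each other. A step within the scatter is therefore expected in this assay, with compound 4 estimated at 150 nM (range 60 nM to 400 nM), meaning a 1.2-fold higher number from compound 3 to compound 4 (0.07 log units; within the scatter).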

Compound 4, inhibition constant: 411 nM
For compound 4 the middle estimate is 2.7-fold (0.44 log units) below the measured one; measured number outside the range, above it.
By their numbers in this assay, from the lowest: compounds 3 and 2 (each within the scatter of the next); then compounds 4 and 1 (each within the scatter of the next).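

In this assay, the count of heavy atoms does not settle the result at this aromatic carbon: isopropyl and cyclopropyl each hold three carbons, yet closing them into a ring gives a clear loss (a 3.2-fold higher number from compound 3 to compound 4 (0.51 log units; beyond the scatter)). The 4-cyclopropylphenyl group also trails 3,4-dichlorophenyl (a 2.1-fold higher number from compound 2 to compound 4 (0.31 log units; beyond the scatter)), while cyclopropyl and bromo cannot be told apart (a 1.0-fold lower number from compound 1 to compound 4 (0.00 log units; within the scatter)). Nothing available here explains this difference. As far as these compounds go, whether a tert-butyl or methoxy group at this carbon would match isopropyl remains open, as does whether the isopropyl-to-cyclopropyl loss persists on a changed core.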